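Cyano in place of methyl on the shared core

This account rests on a few compounds, and the source may have more. Where it says the series, first, only, none or still open, it means among the compounds named here.

Measured so far in an ADME assay on BJ cells (Homo sapiens) for cytotoxicity, read by CellTiter-Glo, with a stated time of 72 h; on this read-out lower numbers stand for an effect already at smaller amounts and higher numbers for an effect only at larger amounts of compound
compound 1 `CC1=C2CC(C)(C)/C=C/C/C(C)=C\C3=C[C@H](C)C[C@]3(O2)C1=O` gives 26000 nM
compound 2 `CC1=C2CC(C)(C)/C=C/C(=O)/C(C)=C\C3=C[C@H](C)C[C@]3(O2)[C@@]1(O)C(F)(F)F` gives 26000 nM
compound 3 `CC1=C2CC(C)(C)/C=C/C(=O)/C(C)=C\C3=C[C@H](C)C[C@]3(O2)[C@]1(C)O` gives 26000 nM

Compound 3 stands level with compound 1 and compound 2 in this assay and nothing separates the three. Compound 4 `CC1=C2CC(C)(C)/C=C/C(=O)/C(C)=C\C3=C[C@H](C)C[C@]3(O2)[C@@]1(O)C#N` brings cyano in place of methyl on a saturated ring carbon. Going by the values given here, the one measured exchange at this carbon, methyl in place of trifluoromethyl, gave no change at the digits printed from compound 2 to compound 3 (within the scatter). Cyano itself is untested in the series, so this single step is thin support. The expected result in this assay is no change at the digits printed from compound 3 to compound 4 (within the scatter), with no step beyond the scatter and more room towards smaller amounts. For compound 4 the estimated value is 26000 nM, with an expected range of 9000 nM to 32000 nM.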

Compound 4, half-maximal effective concentration: 26000 nM
Compound 4: the middle estimate sits on the measured number at the digits printed, within the range that was stated.
By their numbers in this assay, from the lowest: compounds 1, 2, 3 and 4 (each within the scatter of the next).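

In this assay, cyano in place of methyl gives no change at the digits printed from compound 3 to compound 4 (within the scatter) and cyano in place of trifluoromethyl gives no change at the digits printed from compound 2 to compound 4 (within the scatter) at this saturated ring carbon. The position thus goes from one readable exchange to three groups that are not separated, and the entering triple bond and hydrogen-bond acceptor counted for cyano bring no step beyond the scatter. Nothing measured bears on why these values coincide.

On these data alone, whether any group at this carbon can move the read-out remains open. An amine, a carboxylic acid or a longer chain such as ethyl would be the next groups to compare here.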